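This account rests on a few compounds, and the source may have more. Where it says the series, first, only, none or still open, it means among the compounds named here.

Measured so far:
compound 1, `CCNc1cc(-c2ccc(NC(=O)Nc3ccc(C)cc3)cc2C)ccn1`, 47.5%
compound 2, `CCNc1cc(-c2ccc(NC(=O)Nc3cccc(Cl)c3)cc2C)ccn1`, 82.7%

In an assay on isolated protein for inhibition of serine/threonine-protein kinase PLK1 (Homo sapiens), read by radiometric assay and 33P incorporation, with a stated time of 40 min, tested at 20 uM, in the presence of a further agent that is not named here (on this read-out lower numbers stand for less inhibition and higher numbers for more inhibition at the one concentration tested (going by the name of the read-out)), compound 2 gives 82.7%, the higher of the two numbers recorded so far; compound 1 gives 47.5%. For the measured compounds named here, the only measured change on the amide-type nitrogen is a number 35.2 percentage points higher from compound 1 to compound 2 (beyond the scatter), a large step that lies well beyond the scatter.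

Compound 3, `CCNc1cc(-c2ccc(NC(=O)Nc3ccc(OC)cc3)cc2C)ccn1`, is not yet measured. It differs from compound 2 by 4-methoxyphenyl in place of 3-chlorophenyl on an amide-type nitrogen. The step from compound 1 to compound 2 bears on this change: it exchanged a 4-methylphenyl for a 3-chlorophenyl and raised inhibition sharply. Compound 3 carries a 4-methoxyphenyl, which resembles the 4-methylphenyl of compound 1 more than the 3-chlorophenyl of compound 2, so a fall back toward the level of compound 1 is expected, though with a single step as guide the size is uncertain. The expected step is a number 32.7 percentage points lower from compound 2 to compound 3 (beyond the scatter). Compound 3 is therefore estimated at 50%, within a range from 30% to 72%.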

Compound 3, a percentage reported as inhibition, at one concentration (the size of the read-out at that concentration, not a potency): 45.8%
Estimate against measurement, compound 3: 4.2 percentage points above; the range from low to high includes it.
By their numbers in this assay, from the lowest: compounds 3 and 1 (each within the scatter of the next); then compound 2.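

In this assay, putting 4-methoxyphenyl in place of 3-chlorophenyl on the amide-type nitrogen gives a number 36.9 percentage points lower from compound 2 to compound 3 (beyond the scatter), so the high inhibition seen with compound 2 does not carry over to this second group. Methoxy in place of methyl on the aromatic carbon gives a number 1.7 percentage points lower from compound 1 to compound 3 (within the scatter), which means that the two 4-substituted phenyl groups cannot be told apart here, and that among these three compounds only the 3-chlorophenyl group stands out, with no compound going against this. Nothing measured here explains why these groups differ in this way.

Going by these compounds, what remains open is whether the chlorine itself or its place on the ring accounts for the gap, since compounds 1, 2 and 3 change the substituent and its ring position together, and a 4-chlorophenyl or a 3-methylphenyl group would separate the two. On these data alone, it is also open how an unsubstituted phenyl group or a 3-methoxyphenyl group would compare, and how far the differences at this single concentration would hold as differences in potency.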